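Series notes: solubility step from compound 3 to compound 4

A few compounds are considered here, and "the series" means these few. Any claim that something is new, unique, unknown or untested is made for them only; others in the source may bear on it.

Compound 1 `CCc1ccc(-c2nc3c(c(C)nn3-c3ccccc3)c(-c3ccccc3Cl)c2C#N)cc1` gives 1700 nM in a physicochemical assay for solubility, read by spectrophotometry, in phosphate buffer, with a stated time of 18 h, at pH 7.4; on this read-out lower numbers stand for lower solubility and higher numbers for higher solubility. Among the compounds with values here, compound 2 `C#Cc1ccccc1-c1c(C#N)c(-c2ccc(CC)cc2)nc2c1c(C)nn2-c1ccccc1` gives 46000 nM in this assay, and the one measured step, a 27-fold higher number from compound 1 to compound 2 (1.43 log units; beyond the scatter), is large. Compound 3 `Cc1nn(-c2ccccc2)c2nc(-c3ccc(C(C)C)cc3)c(C#N)c(-c3ccccc3O)c12` gives 9800 nM in this assay, the second highest of the three numbers, nearer to compound 2 than to compound 1. Compound 4 `Cc1nn(-c2ccccc2)c2nc(-c3ccc(S(C)(=O)=O)cc3)c(C#N)c(-c3ccccc3O)c12` is not yet measured; it differs from compound 3 by methylsulfonyl in place of isopropyl on an aromatic carbon. Within the data shown here, no measured step shares this change; the single step available concerns chloro to ethynyl, a different group. With no direct guide, a moderate rise is expected for compound 4, a 3.1-fold higher number from compound 3 to compound 4 (0.49 log units; beyond the scatter). Compound 4 is expected to give 30000 nM in this assay, within 10000 nM to 90000 nM.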

Compound 4, solubility: 5000 nM
Estimate against measurement, compound 4: 6.0-fold (0.78 log units) above, and the stated range ends above it.
By their numbers in this assay, from the lowest: compound 1; then compounds 4 and 3 (each within the scatter of the next); then compound 2.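

In this assay, methylsulfonyl in place of isopropyl gives a 2.0-fold lower number from compound 3 to compound 4 (0.29 log units; within the scatter) at the position para to a large group. Within the data shown here, this is the first reading at this position, and a swap that brings in hydrogen-bond acceptors and a sulfur atom leaves the number within the scatter. No measurement at hand accounts for this result.

Open, from the compounds shown here alone, is how an amine or a carboxylic acid would read at this position. Also open, going by these compounds, is whether methylsulfonyl would read the same in compounds carrying the chloro of compound 1 or the ethynyl of compound 2.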